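The source may report more compounds than this note shows. Statements on the series, on what has been measured and on what is new or still open speak of the compounds shown alone.

Compound 1 `Clc1cccc(-n2ncnc2NCc2ccccc2)c1Cl` — 47.9 nM
Compound 2 `Cc1ccccc1CNc1ncnn1-c1cccc(Cl)c1Cl` — 20.9 nM
Compound 3 `Clc1cccc(-n2ncnc2NCc2cccnc2)c1Cl` — 117 nM

All three compounds were tested in a functional assay for antagonist activity at P2X purinoceptor 7 (Homo sapiens), read by FLIPR and calcium flux; on this read-out lower numbers stand for stronger inhibition and higher numbers for weaker inhibition. Compound 3 gives the highest number of the three; its nearest neighbour is compound 1, and the gap between them, a 2.4-fold higher number from compound 1 to compound 3 (0.39 log units; beyond the scatter), is beyond the scatter. The gap to compound 2, a 5.6-fold higher number from compound 2 to compound 3 (0.75 log units; beyond the scatter), is larger still. Compound 3 is thus the weakest inhibitor among the measured compounds.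

Compound 4 `Cc1ncccc1CNc1ncnn1-c1cccc(Cl)c1Cl` has not yet been measured. It differs from compound 3 by a single change: methyl in place of hydrogen on an aromatic carbon.

For the measured compounds named here, one measured step bears directly on this change. Going from compound 1 to compound 2 adds a methyl to the phenyl ring on the saturated chain carbon, and the number fell, a 2.3-fold lower number from compound 1 to compound 2 (0.36 log units; beyond the scatter), a modest shift beyond the scatter. The change from compound 3 to compound 4 places a methyl on the corresponding pyridin-3-yl ring in the same manner. If the pyridine ring behaves like the phenyl ring in this respect, a similar modest drop in the number is expected for compound 4.

Compound 4 is therefore expected to come in at 50 nM, with a range of 20 nM to 130 nM, which corresponds to an expected step of a 2.3-fold lower number from compound 3 to compound 4 (0.37 log units; beyond the scatter).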

Compound 4, half-maximal inhibitory concentration: 11.8 nM
Compound 4: the middle estimate sits 4.2-fold (0.63 log units) above what was measured, and the stated range ends above it.
By their numbers in this assay, from the lowest: compounds 4 and 2 (each within the scatter of the next); then compound 1; then compound 3.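

In this assay, a methyl on an aromatic carbon next to the ring nitrogen lowers the number (a 9.9-fold lower number from compound 3 to compound 4 (1.00 log units; beyond the scatter)), and it counts for more on the pyridin-3-yl ring than the same change does on the phenyl ring: (the same change on two cores in this assay, a 2.3-fold lower number (0.36 log units; beyond the scatter) from compound 1 to compound 2 and a 9.9-fold lower number (1.00 log units; beyond the scatter) from compound 3 to compound 4, 4.3-fold (0.64 log units) apart, beyond the scatter of two such steps). The 2-methylpyridin-3-yl group of compound 4 also does more than make up the ground that pyridin-3-yl gave up against phenyl, since the step to it from the unmethylated phenyl compound runs the other way (a 4.1-fold lower number from compound 1 to compound 4 (0.61 log units; beyond the scatter)). The ring nitrogen made a difference beyond the scatter while no methyl was present (a 2.4-fold higher number from compound 1 to compound 3 (0.39 log units; beyond the scatter)), but with the methyl in place, the 2-methylpyridin-3-yl and 2-methylphenyl groups cannot be told apart (a 1.8-fold lower number from compound 2 to compound 4 (0.25 log units; within the scatter)).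

The compounds shown do not reveal why the methyl counts for more on the pyridine ring, and they cover only this one carbon and this one group. On these data alone, it remains open whether an ethyl group, a methoxy group or a chlorine atom at this place would give a number like that of compound 4, and what a methyl would do on another carbon of the ring.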